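The source may report more compounds than this note shows. Statements on the series, on what has been measured and on what is new or still open speak of the compounds shown alone.

In an ADME assay on Caco-2 cells (Homo sapiens) for permeability, tested at 50 uM (on this read-out higher numbers stand for higher permeability and lower numbers for lower permeability), compound 2 `COc1cc(C)c(S(=O)(=O)N(C)CCOCC(=O)N2CCN(C3CCN(C4CC4)CC3)CC2)c(C)c1` gives 11.8 10^-6 cm/s, the highest of the three numbers and beyond the scatter of both others. Compound 1 `COc1cc(C)c(S(=O)(=O)N(C)CCOCC(=O)N2CCC(C3CCN(C)CC3)CC2)c(C)c1` gives 2.6 10^-6 cm/s, and compound 3 `COc1cc(C)c(S(=O)(=O)N(C)CCOCC(=O)N2CCC(C(O)CN(C)C)CC2)c(C)c1` gives 1.3 10^-6 cm/s. Compound 4 `COc1cc(C)c(S(=O)(=O)N(C)CCOCC(=O)N2CCN([C@H]3CN4CCC3CC4)CC2)c(C)c1` departs from compound 2 through one change: a group of 8 heavy atoms (7 carbon, 1 nitrogen; 2 six-membered non-aromatic rings with 1 hetero atom each) in place of a group of 9 heavy atoms (8 carbon, 1 nitrogen; one three-membered non-aromatic ring of carbon only, one six-membered non-aromatic ring with 1 hetero atom), on an amine nitrogen in a ring. Going by the values given here, no measured step covers this change. Among the compounds with values here, the only step between compounds differing in one place, a 2.0-fold lower number from compound 1 to compound 3 (0.30 log units; within the scatter), lies within the scatter and concerns a different group, with 2-(dimethylamino)-1-hydroxyethyl in place of 1-methylpiperidin-4-yl on a saturated ring carbon. It therefore offers little guidance on size. The remaining clue is the position of compound 2 at 11.8 10^-6 cm/s, at the top of the series, which leaves a lower number as the more likely direction in this assay. A modest fall is expected, only somewhat beyond the scatter, and the expected step is a 2.4-fold lower number from compound 2 to compound 4 (0.37 log units; beyond the scatter). For compound 4 the estimated value is 5 10^-6 cm/s, with an expected range of 1.8 10^-6 cm/s to 12 10^-6 cm/s.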

Compound 4, apparent permeability: 1.9 10^-6 cm/s
For compound 4 the middle estimate is 2.6-fold (0.42 log units) above the measured one, within the range that was stated.
By their numbers in this assay, from the lowest: compounds 3, 4 and 1 (each within the scatter of the next); then compound 2.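

In this assay, the change on the amine nitrogen in a ring gives a 6.2-fold lower number from compound 2 to compound 4 (0.79 log units; beyond the scatter), which shows that the read-out responds to the group at this position. Going by these compounds alone, this step lies beyond the scatter, whereas the only earlier step, a 2.0-fold lower number from compound 1 to compound 3 (0.30 log units; within the scatter), lay within it and concerned a saturated ring carbon; here the two groups match in their counts of hydrogen-bond donors and acceptors and neither carries a net charge, so those counts do not separate them. No measurement shown here accounts for the step.

Within the data shown here, with only one change at this position, the compounds leave open whether the size of the step goes with the pair of six-membered rings or with the defined stereocentre. From the compounds shown here alone, how a 1-isopropylpiperidin-4-yl group or an open-chain dimethylaminoethyl group would read on the same nitrogen also remains open.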